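A few compounds are considered here, and "the series" means these few. Any claim that something is new, unique, unknown or untested is made for them only; others in the source may bear on it.

In an ADME assay on Jurkat cells (Homo sapiens) for cytotoxicity, read by MTT assay, with a stated time of 72 h (on this read-out higher numbers stand for weaker inhibition and lower numbers for stronger inhibition), compound 1 (`COC(=O)c1ccc(Oc2ccc3c(c2)B(O)OC3)cn1`) gives > 100000 nM as its reading, which is a limit of the assay and not a number. For the measured compounds named here, compound 2 (`NC(=O)c1cnc(Oc2ccc3c(c2)B(O)OC3)cn1`) gives 48200 nM in this assay and so holds the only actual number in this small set. Going by the values given here, compound 3 (`CN(C)C(=O)c1cnc(Oc2ccc3c(c2)B(O)OC3)cn1`) keeps the rest of compound 2 and carries dimethylamino in place of amino on a carbonyl carbon as its single change. Among the compounds with values here, no measured step covers this kind of change, so the expectation rests on compound 2 alone at 48200 nM and no step beyond the scatter is expected in this assay in either direction. The step expected is a 1.1-fold higher number from compound 2 to compound 3 (0.06 log units; within the scatter) in size. For compound 3 the estimated value is 55000 nM with 22000 nM to 100000 nM as the expected range.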

Compound 3, half-maximal inhibitory concentration: > 100000 nM
Compound 3: no number, only a limit (the forecaster's own chance of this, stated with the estimate: 30%); at least 1.8-fold (0.25 log units) between middle value and limit.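

In this assay, the step gives this position its first one-place comparison: dimethylamino in place of amino on a carbonyl carbon, whose other neighbour is an aromatic carbon, yields an at least 2.0-fold higher number from compound 2 to compound 3 (0.31 log units; beyond the scatter). The earlier compounds shown here could not show this, as compound 1 differs from compound 2 in more than one place. This step is a lower bound and not a full measure of the change: the limit of > 100000 nM in this assay, at which 2 of the 3 values shown sit.

The compounds shown leave open how methylamino, with a single methyl on the nitrogen, would read on the same carbonyl carbon. They also leave open whether a cyclic amine such as morpholine or a carboxylic acid in that place would give an actual number in this assay.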